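Trimming a Methoxy Group: From Compound 2 to Compound 4

The compounds below may be only part of what the source reports. "The series", "measured", "known", "first", "only" and "open" are said of these compounds alone.

compound 1, `COc1ccc(-c2cc(/C=C/C(=O)c3ccc(N)cc3)[nH]n2)cc1`: 8%
compound 2, `COc1cc(-c2cc(/C=C/C(=O)c3ccc(N)cc3)[nH]n2)cc(OC)c1OC`: -19%
compound 3, `COc1ccc(C(=O)/C=C/c2cc(-c3cc(OC)c(OC)c(OC)c3)n[nH]2)cc1OC`: -36%

In a functional assay on NCI-H23 cells (Homo sapiens) for cytotoxicity, read by sulforhodamine B assay, with a stated time of 48 h, tested at 10 uM (on this read-out lower numbers stand for a stronger effect and higher numbers for a weaker effect at the one concentration tested), compound 2 gives -19%, the second highest of the three numbers. The nearest number belongs to compound 3, reached by a number 17 percentage points lower from compound 2 to compound 3 (beyond the scatter), where the change is 3,4-dimethoxyphenyl in place of 4-aminophenyl on a carbonyl carbon. Compound 1 lies farther away, its number higher than that of compound 2 by more than the scatter.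

Compound 4, `COc1ccc(-c2cc(/C=C/C(=O)c3ccc(N)cc3)[nH]n2)cc1OC`, has not yet been measured in this assay. It differs from compound 2 in one place: hydrogen in place of methoxy on an aromatic carbon. Among the compounds with values here, the only measured step, from compound 2 to compound 3, alters a different part of the molecule and so says little about this change. Compound 1, which carries fewer methoxy groups on that ring than compound 4, shows the higher number of the three, so compound 4 is expected to fall between compound 2 and compound 1. For compound 4 the expected step is a number 14 percentage points higher from compound 2 to compound 4 (beyond the scatter), upward. Compound 4 is estimated to give -5%, within -25% to 15%.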

Compound 4, a percentage reported as activity, at one concentration (the size of the read-out at that concentration, not a potency): 21%
For compound 4 the middle estimate is 26 percentage points below the measured one; measured number outside the range, above it.
By their numbers in this assay, from the lowest: compound 3; then compound 2; then compound 1; then compound 4.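

In this assay, hydrogen in place of methoxy on an aromatic carbon gives a number 40 percentage points higher from compound 2 to compound 4 (beyond the scatter), so this one position, ortho to a methoxy group, has a large effect on the read-out. The reverse kind of change on the ring of compound 1, methoxy in place of hydrogen on an aromatic carbon, gives a number 13 percentage points higher from compound 1 to compound 4 (beyond the scatter), so compound 4 sits above both of its neighbours and adding methoxy groups to this ring does not move the number steadily in one direction. Nothing available explains why these steps take this size or direction.

As far as these compounds go, what a hydroxy group, a chlorine atom or an ethoxy group would do at this position remains open. So does whether the same swap of methoxy for hydrogen would give a similar step with the 3,4-dimethoxyphenyl group of compound 3 on the carbonyl carbon.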